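A few compounds are considered here, and "the series" means these few. Any claim that something is new, unique, unknown or untested is made for them only; others in the source may bear on it.

The measured compounds:
compound 1, `CCOC(=O)c1c(C)nc(-c2ccc(OCC(C)C)c(C#N)c2)n1O`, in a functional assay on a cell-free system (plasma, Oryctolagus cuniculus) for inhibition, with stated times of 5 min, 1 min and 6 min (a lower number here means a stronger inhibitor, a higher number a weaker inhibitor), gives 16800 nM
compound 2, `CCOC(=O)c1c(C)nc(-c2ccc(C#N)cc2)n1OC`, gives 13400 nM
compound 3, `CCOC(=O)c1c(C)nc(-c2cccc(C#N)c2)n1OCc1ccncc1`, gives 6200 nM

Compound 3 stands lowest of the three numbers. Its nearest neighbour is compound 2, whose number is higher by a margin beyond the usual scatter, and compound 1 lies furthest, also beyond the scatter. No two of these compounds differ in only one place, so no single step between measured compounds can be read off; each pair shows only what its two values show, and the three differ in several places at once.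

Compound 4, `CCOC(=O)c1c(C)nc(-c2cccc(C#N)c2)n1OCc1ccccc1C#N`, has not yet been measured in this assay. Its difference from compound 3 is counted as follows: 2-cyanophenyl in place of pyridin-4-yl on a saturated chain carbon bound to an oxygen on an aromatic ring. For the measured compounds named here, nothing among the measured compounds speaks directly to this exchange: compound 3 is the only one carrying a (pyridin-4-yl)methyl, and no measured compound carries a 2-cyanobenzyl. The expected step is therefore modest and uncertain in direction, a 1.0-fold lower number from compound 3 to compound 4 (0.01 log units; within the scatter), likely within the scatter. Compound 4 is expected to give about 6000 nM in this assay, within a range from 2500 nM to 15000 nM.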

Compound 4, half-maximal inhibitory concentration: 9380 nM
Beside the measured number, compound 4's estimate is 1.6-fold (0.19 log units) below it, and the stated range covers the measured number.
By their numbers in this assay, from the lowest: compounds 3, 4, 2 and 1 (each within the scatter of the next, the first and the last beyond it).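

In this assay, for the compounds shown here, the exchange of pyridin-4-yl for 2-cyanophenyl on a saturated chain carbon bound to an oxygen on an aromatic ring gives a 1.5-fold higher number from compound 3 to compound 4 (0.18 log units; within the scatter) and thus offers the first reading of a single change, one that leaves compound 3 and compound 4 indistinguishable. For this pair, then, an aromatic ring of carbon only carrying a nitrile can stand where the pyridin-4-yl stood without a shift that exceeds the scatter, so the ring nitrogen of the pyridin-4-yl is not needed for a number of this size when 2-cyanophenyl takes its place. Nothing at hand explains why the two compounds fall so close together, as no supporting measurement bears on this result.

The compounds shown leave open whether the nitrile on the benzyl ring contributes anything at all, a question that plain benzyl would address, and whether the same holds for a ring bearing a carboxylic acid or for a saturated ring amine such as piperidin-4-yl on the same chain carbon. They also leave open whether this exchange would read the same on a different substitution of the shared core.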